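Hexylphenyl series: propiolate ester versus bromoethyl ketone

The source may report more compounds than this note shows. Statements on the series, on what has been measured and on what is new or still open speak of the compounds shown alone.

Measured so far, in an in vitro assay on BL21-DE3 cells for displacement of a labelled ligand from thyroid hormone receptor beta (Homo sapiens), read by fluorescence polarization; on this read-out lower numbers stand for stronger inhibition and higher numbers for weaker inhibition:
compound 1 `CCCCCCc1ccc(C(=O)CCN(C(C)C)C(C)C)cc1` gives 2000 nM
compound 2 `C#CC(=O)Oc1ccc(CCCCCC)cc1` gives 6200 nM

Compound 2 stands at the higher of the two numbers, and its gap to compound 1 lies beyond the scatter. Compound 3 `CCCCCCc1ccc(C(=O)CCBr)cc1` is not yet measured. It differs from compound 2 by (2-bromoethyl)carbonyl in place of (ethynylcarbonyl)oxy on an aromatic carbon. Going by the values given here, no measured step covers this change. Compound 3 shares its hexylphenyl core and a carbonyl-bearing side group with compound 1, so the number is expected to fall between those of compound 1 and compound 2, a modest step of a 2.1-fold lower number from compound 2 to compound 3 (0.32 log units; beyond the scatter) that may not clear the scatter. For compound 3 the estimate is 3000 nM, within 1000 nM to 9000 nM.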

Compound 3, half-maximal inhibitory concentration: 3000 nM
For compound 3 middle estimate and measured number coincide at the digits printed, within the range that was stated.
By their numbers in this assay, from the lowest: compounds 1 and 3 (each within the scatter of the next); then compound 2.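

In this assay, (2-bromoethyl)carbonyl in place of (ethynylcarbonyl)oxy on the aromatic carbon gives a 2.1-fold lower number from compound 2 to compound 3 (0.32 log units; beyond the scatter), so this position responds modestly to the exchange. Along the chain, bromo in place of diisopropylamino gives a 1.5-fold higher number from compound 1 to compound 3 (0.18 log units; within the scatter), so these two end groups cannot be told apart here. No data on hand account for either step.

The step from compound 2 to compound 3 changes the linking atoms and the end of the group together, and a 2-bromoethyl ester or an ethynyl ketone would separate the two. From the compounds shown here alone, whether a carboxylic acid at the chain end or a longer chain in place of hexyl shifts the number remains open.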